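A few compounds are considered here, and "the series" means these few. Any claim that something is new, unique, unknown or untested is made for them only; others in the source may bear on it.

Three compounds that share a trifluoromethyl-bearing aromatic core carrying an amide have been tested in a functional assay on HL-60 cells (Homo sapiens) for cytotoxicity, read by MTT assay, with a stated time of 48 h; a higher number here means a weaker inhibitor, a lower number a stronger inhibitor. Compound 1 `O=C(Nc1cc(C(F)(F)F)ccc1N1CCCC1)c1cccnc1Cl` carries a pyrrolidine on the core and a 2-chloropyridin-3-yl on the carbonyl; in this assay compound 1 is reported as "not active" (no number reported). Compound 2 `CCN(CC)c1ccc(C(F)(F)F)cc1NC(=O)c1ccncc1` carries a diethylamino group and a pyridin-4-yl on the carbonyl; in this assay compound 2 gives 89700 nM. Compound 3 `CCN(CC)c1ccc(C(F)(F)F)cc1NC(=O)c1ccccc1` keeps the diethylamino group and carries a plain phenyl on the carbonyl; in this assay compound 3 is reported as "not active" (no number reported), so no number stands for it, only the statement that no inhibition was seen. Among the three, only compound 2 has a numerical read-out, and it is a weak one.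

Compound 4 `CCN(CC)c1ccc(C(F)(F)F)cc1NC(=O)c1cccnc1Cl` is the next member of the set. Relative to compound 3 it brings in a (2-chloropyridin-3-yl in place of phenyl on a carbonyl carbon). Among the compounds with values here, no measured pair shows what this exchange does on its own. The nearest guidance is that compound 1, which already carries the 2-chloropyridin-3-yl, is reported as "not active" (no number reported), and that compound 2, with a different pyridine, reaches only 89700 nM. Any gain over compound 3 is therefore expected to be modest at best, and a second report of no activity is quite possible. For compound 4 in this assay the estimate is 100000 nM, with a plausible range from 30000 nM to 300000 nM.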

Compound 4, half-maximal inhibitory concentration: 84100 nM
Compound 4: the middle estimate sits 1.2-fold (0.08 log units) above what was measured; low and high end bracket the measured number.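

In this assay compound 3, with its plain phenyl on the carbonyl carbon, stands as "not active" (no number reported) while compound 4, with a 2-chloropyridin-3-yl there, gives 84100 nM and so shows that this exchange goes with a measurable but still weak read-out, although no size can be put on the change without a number for compound 3. The two pyridine groups cannot be told apart at this position (a 1.1-fold lower number from compound 2 to compound 4 (0.03 log units; within the scatter)), yet a pyridine group alone does not ensure a numerical read-out: compound 1 goes against that idea, since it carries the same 2-chloropyridin-3-yl with a pyrrolidine in place of the diethylamino group and stands as "not active" (no number reported) in this comparison. Nothing measured here explains these results.

The compounds shown leave open what the chlorine contributes, as a plain pyridin-3-yl on the carbonyl carbon would be needed to separate it from the ring nitrogen. They also leave open whether a different group at this position, such as an aminomethyl or a carboxylic acid on the ring, could bring the number far below this weak range.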